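Shortening the side chain: compound 4 of the series

This account rests on a few compounds, and the source may have more. Where it says the series, first, only, none or still open, it means among the compounds named here.

Three esters sharing one core have been run in a functional assay on the whole organism (Tail, strain ICR) with Mus musculus as the target, in the tail flick test, with a stated time of 120 min, at a dose of 25 umol/kg by the oral route; a higher number here means a stronger effect of the compound at the dose given, a lower number a weaker effect. Compound 1 `N=C(N)NCCC[C@H](NC(=O)CN(c1ncnc2c1ncn2C1CCCCO1)C1CC1)C(=O)OCc1ccccc1` gives 38.2%. Compound 2 `CC(C)[C@H](NC(=O)CN(c1ncnc2c1ncn2C1CCCCO1)C1CC1)C(=O)OCc1ccccc1` gives 25.8%, and compound 3 `CSCC[C@H](NC(=O)CN(c1ncnc2c1ncn2C1CCCCO1)C1CC1)C(=O)OCc1ccccc1` gives 28.7%. Compound 3 thus stands second of the three numbers, yet both neighbours lie within the scatter of it, so no order among them is secure.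

Compound 4 `C[C@H](NC(=O)CN(c1ncnc2c1ncn2C1CCCCO1)C1CC1)C(=O)OCc1ccccc1` is not yet measured. It differs from compound 3 as follows: hydrogen in place of (methylsulfanyl)methyl on a saturated chain carbon, two bonds along the chain from an amide-type nitrogen and a carbonyl carbon.

Among the compounds with values here, the measured steps that bear on a smaller group at this carbon all point the same way. a number 12.4 percentage points lower from compound 1 to compound 2 (beyond the scatter) is the only step beyond the scatter; a number 9.5 percentage points lower from compound 1 to compound 3 (within the scatter) and a number 2.9 percentage points higher from compound 2 to compound 3 (within the scatter) stay inside it. Replacing a larger group by a smaller one has so far lowered or left unchanged the read-out, never raised it.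

For compound 4 a small downward step is therefore expected, a number 5.7 percentage points lower from compound 3 to compound 4 (within the scatter), because compound 1 to compound 2 showed a number 12.4 percentage points lower from compound 1 to compound 2 (beyond the scatter) for a comparable loss of chain. The estimate for compound 4 is 23%, expected to fall between 11% and 35%.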

Compound 4, a percentage reported as activity, at one dose (the size of the read-out at that dose, not a potency): 25.3%
The estimate for compound 4 lay 2.3 percentage points below the measured number, within the range that was stated.
By their numbers in this assay, from the lowest: compounds 4, 2, 3 and 1 (each within the scatter of the next, the first and the last beyond it).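

In this assay, within the data shown here, shortening the side chain all the way to methyl gives no step that can be told from the scatter: a number 3.4 percentage points lower from compound 3 to compound 4 (within the scatter), and a number 0.5 percentage points lower from compound 2 to compound 4 (within the scatter), so methyl, isopropyl and 2-(methylsulfanyl)ethyl cannot be separated at this carbon. The chain of compound 1 does stand apart from methyl, a number 12.9 percentage points lower from compound 1 to compound 4 (beyond the scatter), but compound 3 goes against a clean split, as it remains within the scatter of compound 1 while also within the scatter of compound 4. No measurement bears on why the chain of compound 1 gives the higher number.

On these data alone, it remains open whether an amine or a carboxylic acid at the end of a longer chain on this carbon would read with compound 1 or with compound 4. With one dose and one time point, these numbers give the size of the effect only, not a potency.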